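A Ketone in Place of a Tertiary Alcohol

The source may hold more compounds than are shown below. What is called first, only, known or untested is meant among the compounds shown, and "the series" means these compounds.

Compound 1 `Cc1c(O)cc(CCCCC(C)(C)O)oc1=O` was examined in a functional assay on HCT-116 cells (Homo sapiens) for cytotoxicity, read by MTT assay (on this read-out higher numbers stand for weaker inhibition and lower numbers for stronger inhibition), and reached only a limit of the assay; in this assay compound 1 gives > 200000 nM. Compound 2 `CCC(C)CCCCc1cc(O)c(C)c(=O)o1` likewise sits at a limit, giving > 200000 nM. The measured step that the two limits leave unreadable from compound 1 to compound 2 therefore cannot be read, as summarised by the limit of > 200000 nM in this assay, at which 2 of the 2 values shown sit. Compound 3 `CC(=O)C(C)CCCCc1cc(O)c(C)c(=O)o1` carries the change (1-acetylethyl in place of 1-hydroxy-1-methylethyl on a saturated chain carbon, four bonds along the chain from an aromatic carbon). No readable step in the set bears on this change, so compound 3 is expected to remain near the limit, with a number no higher from compound 1 to compound 3 (the limit leaves the size open) estimated as no step beyond the scatter. Compound 3 is estimated at 200000 nM, between 80000 nM and 500000 nM.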

Compound 3, half-maximal inhibitory concentration: > 200000 nM
Compound 3 gave a limit, no number; the forecaster's own chance of this, stated with the estimate: 80%; the middle value lies on the limit itself.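

In this assay compound 3 gives > 200000 nM, which is a limit, so its steps from compound 1 and from compound 2 cannot be read. The compounds shown leave open whether any of these chain ends differs from another in this assay.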